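This account rests on a few compounds, and the source may have more. Where it says the series, first, only, none or still open, it means among the compounds named here.

Measured so far:
Compound 1 `CCCC[C@@H](O)C(=O)N1C[C@H]2C[C@H]2[C@H]1C(=O)NCc1cc(Cl)ccc1-n1cnnn1`: 32 mL.min-1.g-1
Compound 2 `COC(C)(C)[C@@H](O)C(=O)N1C[C@H]2C[C@H]2[C@H]1C(=O)NCc1cc(Cl)ccc1-n1cnnn1`: 23 mL.min-1.g-1
Compound 3 `CCCC[C@@H](O)C(=O)N1N=CC[C@H]1C(=O)NCc1cc(Cl)ccc1-n1cnnn1`: a limit of the assay, < 12 mL.min-1.g-1

All three were tested in an ADME assay on liver for metabolic stability, with Liver microsome (Homo sapiens) as the target, read by LC-MS, using microsomes; a higher number here means faster removal of the compound, a lower number slower removal. Compound 1 gives 32 mL.min-1.g-1 and compound 2 gives 23 mL.min-1.g-1. For compound 3 the result is only a limit of the assay, < 12 mL.min-1.g-1, not a number. Compound 1 and compound 2 differ in one place, (1-methoxy-1-methylethyl in place of butyl on a saturated chain carbon bound to a carbonyl carbon and an oxygen on a saturated carbon), and that step is a 1.4-fold lower number from compound 1 to compound 2 (0.14 log units; within the scatter). Compound 4 `COC(C)(C)[C@@H](O)C(=O)N1N=CC[C@H]1C(=O)NCc1cc(Cl)ccc1-n1cnnn1` is not yet measured; it differs from compound 3 by 1-methoxy-1-methylethyl in place of butyl on a saturated chain carbon bound to a carbonyl carbon and an oxygen on a saturated carbon, the same change at the same place. The cores of compound 3 and compound 1 differ, but that difference is not broken down here. Of the values shown, (the limit of < 12 mL.min-1.g-1 in this assay, at which 1 of the 3 values shown sits). For compound 4 the expected step is a step that the limit leaves unreadable from compound 3 to compound 4, resting on a 1.4-fold lower number from compound 1 to compound 2 (0.14 log units; within the scatter), which stayed within scatter. Compound 4 is therefore estimated at 8 mL.min-1.g-1, expected between 3 mL.min-1.g-1 and 16 mL.min-1.g-1, most likely reported again only as a limit.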

Compound 4, intrinsic clearance in microsomes: < 12 mL.min-1.g-1
Compound 4: no number, only a limit; the forecaster's own chance of this, stated with the estimate: 70%; the middle value lies beyond the limit too.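

In this assay, among these compounds, compound 3 and compound 4 are both reported only as limits of the assay, so no step between them can be read: the limit of < 12 mL.min-1.g-1 in this assay, at which 2 of the 4 values shown sit.

From the compounds shown here alone, how far 1-methoxy-1-methylethyl in place of butyl moves the number on the core of compound 3 stays open.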